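Aryl variation on the shared core: toward compound 4

The source may report more compounds than this note shows. Statements on the series, on what has been measured and on what is new or still open speak of the compounds shown alone.

Measured so far:
compound 1 `CCN(CC)c1nc(Nc2cccc(Cl)c2)nc(OC(C(F)(F)F)C(F)(F)F)n1` gives 2800 nM in an assay on cells for activation of Cystic fibrosis transmembrane conductance regulator (Homo sapiens), read by fluorescence, with stated times of 10 min and 12 s; a lower number here means that less compound is needed, a higher number that more compound is needed for the effect
compound 2 `CCN(CC)c1nc(Nc2cccc([N+](=O)[O-])c2)nc(OC(C(F)(F)F)C(F)(F)F)n1` gives 200 nM in this assay
compound 3 `CCN(CC)c1nc(Nc2ccc(C(=O)O)cc2)nc(OC(C(F)(F)F)C(F)(F)F)n1` gives 900 nM in this assay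

Compound 3 stands second highest of the three numbers, nearest to compound 1 and furthest from compound 2. Compound 4 `CCN(CC)c1nc(Nc2ccc3[nH]ncc3c2)nc(OC(C(F)(F)F)C(F)(F)F)n1` differs from compound 3 by 1H-indazol-5-yl in place of 4-carboxyphenyl on a nitrogen on an aromatic ring. Within the data shown here, the steps that bear on this change are those altering the same aryl group on the same nitrogen: a 3.1-fold lower number from compound 1 to compound 3 (0.49 log units; beyond the scatter) and a 4.5-fold higher number from compound 2 to compound 3 (0.65 log units; beyond the scatter). Both were modest, in opposite directions, so a modest step in this assay is expected here, with no firm direction; a slightly lower number is estimated for compound 4, a 1.5-fold lower number from compound 3 to compound 4 (0.18 log units; within the scatter). Compound 4 is therefore expected to give about 600 nM, within a range of 150 nM to 2500 nM.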

Compound 4, half-maximal effective concentration: 2800 nM
For compound 4 the middle estimate is 4.7-fold (0.67 log units) below the measured one, and the stated range ends below it.
By their numbers in this assay, from the lowest: compound 2; then compound 3; then compounds 1 and 4 (each within the scatter of the next).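

In this assay, placing 1H-indazol-5-yl on this nitrogen gives a 3.1-fold higher number from compound 3 to compound 4 (0.49 log units; beyond the scatter) and a 14-fold higher number from compound 2 to compound 4 (1.15 log units; beyond the scatter), so a second aromatic ring here does not retain the lower numbers seen with 4-carboxyphenyl or 3-nitrophenyl. Against 3-chlorophenyl, the same group gives no change at the digits printed from compound 1 to compound 4 (within the scatter), so the range at this position now has two aryl groups at its upper end. No available evidence accounts for these differences. From the compounds shown here alone, whether an amine or a nitrile in place of the nitro group of compound 2 would keep its low number remains open.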